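The source may report more compounds than this note shows. Statements on the series, on what has been measured and on what is new or still open speak of the compounds shown alone.

Two compounds built on a shared core have been run through a toxicity assay on HepG2 cells (Homo sapiens) for inhibition, read by CellTiter-Glo, with a stated time of 48 h; a lower number here means a stronger inhibitor, a higher number a weaker inhibitor. Compound 1 `Cc1cc(C)cc(NC(=O)COc2cc(C)nc3ccc(C(F)(F)F)cc23)c1` carries a trifluoromethyl on the core and a dimethylphenyl on the amide side. In this assay compound 1 reaches only the limit of the measurement, > 100000 nM. Compound 2 `COc1ccc2nc(C)cc(OCC(=O)Nc3ccccc3)c2c1` instead bears a methoxy on the core and a plain phenyl on the amide, and in this assay compound 2 gives 39800 nM. For the measured compounds named here, that makes compound 2 the only one of the pair with a real number; the other result is a limit, as the note the limit of > 100000 nM in this assay, at which 1 of the 2 values shown sits, records. Compound 3 `COc1cccc(NC(=O)COc2cc(C)nc3ccc(OC)cc23)c1` is compound 2 with a single change: methoxy in place of hydrogen on an aromatic carbon, sitting meta to a large group, which read one bond further out is phenyl to 3-methoxyphenyl. Going by the values given here, no measured pair here shows how such a change moves this readout. The step from compound 2 to compound 3 is therefore expected to be small, a 1.1-fold higher number from compound 2 to compound 3 (0.05 log units; within the scatter), with no direction beyond the scatter. Compound 3 is estimated at 45000 nM, within a range from 15000 nM to 120000 nM, and the result could come back as only a limit.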

Compound 3, half-maximal inhibitory concentration: > 100000 nM
Compound 3: no number, only a limit (the forecaster's own chance of this, stated with the estimate: 35%); middle value at least 2.2-fold (0.34 log units) from the limit.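

This is the first pair shown that differs in only one place, and it shows that this spot on the phenyl of the amide side matters in this assay: methoxy in place of hydrogen on an aromatic carbon, meta to a large group, gives an at least 2.5-fold higher number from compound 2 to compound 3 (0.40 log units; beyond the scatter). As far as these compounds go, that step is only a minimum, since compound 3 gives > 100000 nM, which is a limit and not a number, so how far the change really reaches stays unknown. The result also leaves compound 2 as the only compound here with a true number, which means that this change moved the readout out of the range that can be measured: the limit of > 100000 nM in this assay, at which 2 of the 3 values shown sit.

From the compounds shown here alone, whether this step belongs to methoxy itself or would follow any group at this spot remains open, as a fluorine, a hydroxyl or an amine there might move the number by a different amount or in the other direction. The compounds shown also leave open what the trifluoromethyl on the core does alone, as no pair here isolates it from the changes on the amide side.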